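The source may report more compounds than this note shows. Statements on the series, on what has been measured and on what is new or still open speak of the compounds shown alone.

Compound 2 `CSc1ccc(NC(=O)c2cc3ccccc3oc2=O)cc1` and compound 1 `Cc1ccc(NC(=O)c2cc3ccccc3oc2=O)cc1` share one core and differ only in a single group on the outer ring. In an in vitro assay on BTI-TN-5B1-4 cells for inhibition of Amine oxidase [flavin-containing] B (Homo sapiens), read by fluorescence (on this read-out lower numbers stand for stronger inhibition and higher numbers for weaker inhibition), compound 1 gives 710 nM, and compound 2 gives 2840 nM. Compound 2 thus carries the higher of the two numbers, the gap being a 4.0-fold higher number from compound 1 to compound 2 (0.60 log units; beyond the scatter). Compound 3 `O=C(Nc1ccc(F)cc1)c1cc2ccccc2oc1=O` has not been measured; it differs from compound 2 by fluoro in place of methylsulfanyl on an aromatic carbon. For the measured compounds named here, no measured step swaps methylsulfanyl for fluoro directly, so the only step that bears on it is a 4.0-fold higher number from compound 1 to compound 2 (0.60 log units; beyond the scatter), in which methyl gave way to methylsulfanyl and the number rose. Here methylsulfanyl leaves again, so a move back toward the lower number seems likely, though its exact size is unknown. The expected step is therefore a 2.8-fold lower number from compound 2 to compound 3 (0.45 log units; beyond the scatter). Compound 3 is estimated at 1000 nM in this assay, with a range from 300 nM to 3500 nM.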

Compound 3, half-maximal inhibitory concentration: 67 nM
Compound 3: the middle estimate sits 15-fold (1.17 log units) above what was measured; measured number below the stated range.
By their numbers in this assay, from the lowest: compound 3; then compound 1; then compound 2.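

The first pair showed only a modest shift at this position on the outer ring, but fluoro moves the number much further, giving a 42-fold lower number from compound 2 to compound 3 (1.63 log units; beyond the scatter) when it replaces methylsulfanyl and an 11-fold lower number from compound 1 to compound 3 (1.03 log units; beyond the scatter) when it replaces methyl. Losing methylsulfanyl is therefore not the whole story: compound 1 also lacks that group, yet its number stays well above that of compound 3, so the identity of the incoming group matters. Nothing available here explains why fluoro gives so much stronger inhibition.

On these data alone, whether the low number is special to fluoro or shared by chloro or bromo remains open, as does the outcome with an amine or a methoxy group at this place. The compounds also leave open whether fluoro would give a similar gain on a different core.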